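A few compounds are considered here, and "the series" means these few. Any claim that something is new, unique, unknown or untested is made for them only; others in the source may bear on it.

Measured compounds:
compound 1, `CCN1CCN(c2cc(Nc3ccc4sc(C(=O)Nc5c(C)cccc5Cl)cc4c3)nc(C)n2)CC1`, 46.5%
compound 2, `COc1cc2c(Nc3ccc4sc(C(=O)Nc5c(C)cccc5Cl)cc4c3)ncnc2cc1OCCCN1CCN(C)CC1`, 76%

In a functional assay on U-937 cells (Homo sapiens) for inhibition, read by MTT assay and WST assay, with a stated time of 72 h, tested at 10 uM (a higher number here means more inhibition of growth at the concentration tested, a lower number less inhibition of growth), compound 1 gives 46.5%, the lower of the two measured numbers. Compound 2 gives 76%, a number beyond the scatter above compound 1. Compound 3, `Cc1nc(Nc2ccc3sc(C(=O)Nc4c(C)cccc4Cl)cc3c2)cc(N2CCN(C)CC2)n1`, differs from compound 1 by hydrogen in place of methyl on a saturated chain carbon bound to an amine nitrogen in a ring. Among the compounds with values here, no measured pair shows a step of this kind, so nothing in the data points to a change in either direction beyond the scatter. Compound 3 is therefore expected to give about 45%, with a likely range from 30% to 60%. The expected step of a number 1.5 percentage points lower from compound 1 to compound 3 (within the scatter) is accordingly estimated to stay within the scatter.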

Compound 3, percent growth inhibition at one concentration: 40.6%
Compound 3: middle estimate off by 4.4 percentage points, on the high side; the range from low to high includes it.
By their numbers in this assay, from the lowest: compounds 3 and 1 (each within the scatter of the next); then compound 2.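

In this assay, within the data shown here, replacing 4-ethylpiperazin-1-yl with 4-methylpiperazin-1-yl gives a number 5.9 percentage points lower from compound 1 to compound 3 (within the scatter), the only step read at this position. Between ethyl and methyl at this place, the assay therefore does not separate the two compounds. Nothing available here accounts for this result. The compounds shown leave open whether a longer chain, such as propyl, or a hydroxyethyl group at this place would stay within the scatter of compound 1. They also leave open how a piperazine carrying only hydrogen on that amine nitrogen would compare.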